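Amide-side variations on the shared core

The source may hold more compounds than are shown below. What is called first, only, known or untested is meant among the compounds shown, and "the series" means these compounds.

Values so far in an ADME assay on HepG2 cells (Homo sapiens) for inhibition, with a stated time of 72 h; a lower number here means that less compound is needed, a higher number that more compound is needed for the effect:
compound 1 `O=C(CCl)Nc1cccc(-c2nc3ccccc3s2)c1`: 16000 nM
compound 2 `CC(C)(CCl)C(=O)Nc1cccc(-c2nc3ccccc3s2)c1`: > 25000 nM
compound 3 `O=C(Nc1cccc(-c2nc3ccccc3s2)c1)c1cnccc1Cl`: > 25000 nM

Compound 3 sits at a limit of this assay, not at a number; the same limit holds for compound 2 (the limit of > 25000 nM in this assay, at which 2 of the 3 values shown sit). Only compound 1 gives a number, and the step of an at least 1.5-fold higher number from compound 1 to compound 3 (0.19 log units; that floor lies within the scatter) is itself only a floor that lies within the scatter, as is an at least 1.5-fold higher number from compound 1 to compound 2 (0.19 log units; that floor lies within the scatter). The step that the two limits leave unreadable from compound 2 to compound 3 cannot be read at all. Compound 4 `O=C(Nc1cccc(-c2nc3ccccc3s2)c1)c1cnc(Cl)s1` is the next amide variant: 2-chloro-1,3-thiazol-5-yl in place of 4-chloropyridin-3-yl on a carbonyl carbon. For the measured compounds named here, no measured step exchanges one aromatic ring for another on the carbonyl carbon, so the only guidance is that two of three amides on this core, compound 2 and compound 3, reach the limit and compound 1 gives a weak number. For compound 4 the expectation is therefore a step that the limit leaves unreadable from compound 3 to compound 4 that does not move beyond the scatter, most likely again a limit. The estimate for compound 4 is 30000 nM, ranging from 10000 nM to 100000 nM.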

Compound 4, half-maximal effective concentration: > 25000 nM
Compound 4: only a limit was reported (the forecaster's own chance of this, stated with the estimate: 70%); the middle value does not contradict the limit.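

In this assay a second aromatic ring on the carbonyl carbon, the five-membered 2-chloro-1,3-thiazol-5-yl in place of the six-membered 4-chloropyridin-3-yl, again gives only a limit, and compound 4 joins the other amides that yield no number: the limit of > 25000 nM in this assay, at which 3 of the 4 values shown sit.

For the compounds shown here, the one readable step is an at least 1.5-fold higher number from compound 1 to compound 4 (0.19 log units; that floor lies within the scatter); as a floor, it does not set compound 4 apart from compound 1 by more than the usual spread of repeats. The steps among the compounds at the limit cannot be read, so the two aromatic rings cannot be ordered at this position.

From the compounds shown here alone, how far these compounds lie past the limit stays open. Going by these compounds, it is also open whether an aminomethyl group or a longer alkyl chain on the carbonyl carbon would give a number distinct from compound 1 at 16000 nM.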